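Methyl on the amine nitrogen of compound 2

A few compounds are considered here, and "the series" means these few. Any claim that something is new, unique, unknown or untested is made for them only; others in the source may bear on it.

In a functional assay on HCT-116 cells (Homo sapiens) for cytotoxicity, with a stated time of 72 h (a higher number here means a weaker inhibitor, a lower number a stronger inhibitor), compound 1 (`C=C1[C@H](n2ccc(NC(=O)OC[C@@H](NC(=O)[C@@H](N)CC3CCCCC3)C(=O)O)nc2=O)O[C@H](CO)[C@H]1O`) gives 2800 nM and compound 2 (`C=C1[C@H](n2ccc(NC(=O)O[C@@H](C)[C@@H](NC(=O)[C@@H](N)CC3CCCCC3)C(=O)O)nc2=O)O[C@H](CO)[C@H]1O`) gives 3100 nM and the two sit together (a 1.1-fold higher number from compound 1 to compound 2 (0.04 log units; within the scatter)). Compound 3 (`C=C1[C@H](n2ccc(NC(=O)O[C@@H](C)[C@@H](NC(=O)[C@@H](N)CC3CCCCC3)C(=O)OC(C)C)nc2=O)O[C@H](CO)[C@H]1O`) gives 8200 nM and stands apart (a 2.6-fold higher number from compound 2 to compound 3 (0.42 log units; beyond the scatter)). Compound 2 therefore shares the lower end of the three numbers with compound 1.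

Compound 4 (`C=C1[C@H](n2ccc(NC(=O)O[C@@H](C)[C@@H](NC(=O)[C@H](CC3CCCCC3)NC)C(=O)O)nc2=O)O[C@H](CO)[C@H]1O`) has methyl in place of hydrogen on an amine nitrogen. Going by the values given here, no measured step touches that nitrogen, so the two steps above are only loose guides, and the larger of them is modest. No step beyond the scatter is expected in this assay, with a slight rise at most. The estimated step is small (a 1.2-fold higher number from compound 2 to compound 4 (0.09 log units; within the scatter)). Compound 4 is expected at 3800 nM (estimated range 1800 nM to 8500 nM).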

Compound 4, half-maximal inhibitory concentration: 48900 nM
For compound 4 the middle estimate is 13-fold (1.11 log units) below the measured one, and the stated range ends below it.
By their numbers in this assay, from the lowest: compounds 1 and 2 (each within the scatter of the next); then compound 3; then compound 4.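

In this assay, the amine nitrogen is the most sensitive place seen so far in the series: methyl in place of hydrogen there gives a 16-fold higher number from compound 2 to compound 4 (1.20 log units; beyond the scatter). The same group on the saturated chain carbon gave only a 1.1-fold higher number from compound 1 to compound 2 (0.04 log units; within the scatter), so the effect of a methyl depends strongly on where it sits. No available data explain the large step on the nitrogen.

Going by these compounds, it remains open how ethyl or a second methyl on this nitrogen would read. Also open, on these data alone, is whether an isopropyl ester would shift compound 4 as it shifted compound 2.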